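Halogen exchange on a phenylurea: bromo to iodo

The source may hold more compounds than are shown below. What is called first, only, known or untested is meant among the compounds shown, and "the series" means these compounds.

In an ADME assay on the whole organism with Oryza sativa as the target, tested at 10 uM (on this read-out higher numbers stand for a weaker effect at the one concentration tested and lower numbers for a stronger effect), compound 2 `C[C@H](NC(=O)Nc1ccccc1Br)c1ccccc1` gives 102%. Among the measured compounds shown here, its only measured neighbour is compound 1 `COc1ccccc1NC(=O)N[C@@H](C)c1ccccc1`, which in this assay gives 95%; the two numbers sit within the scatter of each other, so neither compound is separated from the other on the evidence available. For the measured compounds named here, the one step that has been measured is the exchange of methoxy for bromo, a number 7 percentage points higher from compound 1 to compound 2 (within the scatter), and it did not move the read-out beyond the scatter.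

Compound 3 `C[C@H](NC(=O)Nc1ccccc1I)c1ccccc1` has not yet been measured. It differs from compound 2 in a single place: iodo in place of bromo on an aromatic carbon. Going by the values given here, no measured pair shows what an iodo for bromo exchange does in this assay; the only comparison at hand, a number 7 percentage points higher from compound 1 to compound 2 (within the scatter), concerned a different group at the same kind of position and stayed within the scatter. On that slender basis no step beyond the scatter is expected for compound 3, and the step of a number 2 percentage points lower from compound 2 to compound 3 (within the scatter) is the estimated consequence. In this assay compound 3 is therefore expected to give about 100%, with a plausible range from 85% to 115%.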

Compound 3, a percentage reported as activity, at one concentration (the size of the read-out at that concentration, not a potency): 98%
Compound 3: middle estimate off by 2 percentage points, on the high side; the measured number falls inside the stated range.
By their numbers in this assay, from the lowest: compounds 1, 3 and 2 (each within the scatter of the next).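

In this assay, iodo in place of bromo on an aromatic carbon ortho to a large group gave a number 4 percentage points lower from compound 2 to compound 3 (within the scatter), so an exchange between two halogens at this place is now measured directly and does not separate the pair. The direct comparison of iodo with methoxy at the same place gave a number 3 percentage points higher from compound 1 to compound 3 (within the scatter), which means that methoxy, bromo and iodo all lie within the scatter of one another on the shared core, and the read-out distinguishes none of the three. No measurement available here offers a reason for this.

The compounds shown leave open whether any group at this place can move the read-out beyond the scatter, since all three groups compared are neutral single substituents and neither an amine nor a carboxylic acid is among them. They also leave open whether the three compounds would stay together at a concentration other than the single one tested, or whether a longer chain in place of the methyl group on the core would change the picture.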